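Mirror-Image Twin of Compound 1 in a Cytotoxicity Test

A few compounds are considered here, and "the series" means these few. Any claim that something is new, unique, unknown or untested is made for them only; others in the source may bear on it.

Measured compounds:
compound 1, `N#Cc1ccc(Cn2nc(-c3cc(Cl)c(NC[C@H](O)CO)nc3F)c3ccccc3c2=O)cc1`: > 100000 nM
compound 2, `COC(=O)c1cc(-c2ccc(F)nc2F)nn(Cc2ccc(Cl)cc2)c1=O`: > 100000 nM
compound 3, `Cc1c(-c2ccc(F)nc2F)nn(Cc2ccc(Cl)cc2)c(=O)c1C`: 52900 nM

All three were examined in an ADME assay on HepG2 2.2.15 cells (Homo sapiens) for cytotoxicity, read by MTT assay, with a stated time of 8 days; on this read-out lower numbers stand for higher toxicity in this test and higher numbers for lower toxicity in this test. Compound 1 yields no number there, only a limit of the assay, > 100000 nM. Compound 2 likewise yields only a limit of the assay, > 100000 nM. Going by the values given here, compound 3 is the one member of the set that gives a measured figure, 52900 nM. Compound 1 therefore stands at the limit of > 100000 nM in this assay, at which 2 of the 3 values shown sit. Among the compounds with values here, no pair of measured compounds differs in a single place, so there is no measured step to calibrate what a small change does in this assay.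

Compound 4, `N#Cc1ccc(Cn2nc(-c3cc(Cl)c(NC[C@@H](O)CO)nc3F)c3ccccc3c2=O)cc1`, is still to be measured in this assay. Set against compound 1, (the two compounds have the same atoms and bonds and differ only in configuration as drawn: 1 of 1 stereo elements differ; a stereocentre at a saturated chain carbon is drawn S in compound 1 and R in compound 4). Nothing in the measured set speaks to the effect of inverting one stereocentre, and compound 1 itself gives only a limit. The expectation is therefore a step of none beyond the scatter, with compound 4 remaining at the limit just as compound 1 does. Compound 4 is estimated at 120000 nM, with a range from 60000 nM to 250000 nM. The expected step is a step that the limit leaves unreadable from compound 1 to compound 4.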

Compound 4, half-maximal cytotoxic concentration: > 100000 nM
Compound 4 gave a limit, no number; the forecaster's own chance of this, stated with the estimate: 75%; the middle value does not contradict the limit.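

Compound 4, like compound 1, gives only a limit of the assay in this assay, so no step can be read between the two: the limit of > 100000 nM in this assay, at which 3 of the 4 values shown sit.

The compounds shown leave open whether the S and R configurations at the saturated chain carbon differ at all in cytotoxicity; neither compound 1 nor compound 4 has a measured figure.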